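The compounds below may be only part of what the source reports. "The series", "measured", "known", "first", "only" and "open" are said of these compounds alone.

Working notes on the series.

Of the compounds shown here, two have been measured in a functional assay on HepG2 cells (Homo sapiens) for cytotoxicity, with a stated time of 24 h; a higher number here means a weaker inhibitor, a lower number a stronger inhibitor. Compound 1 `O=C(N/N=C/c1cc(I)cc(I)c1O)c1ccc(O)cc1` gives 19200 nM. Compound 2 `O=C(N/N=C/c1cc(I)c(O)c(I)c1)c1ccccc1` gives 191000 nM, the higher of the two numbers, so compound 2 stands as the weaker inhibitor of the pair by a margin that lies beyond the scatter of this assay . For the measured compounds named here, the two compounds differ in more than one place, so no single step between them can be read; the numbers alone show the gap.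

Compound 3 `O=C(N/N=C/c1cc(I)c(O)c(I)c1)c1ccc(Cl)cc1` has not been measured. It differs from compound 2 in one place: chloro in place of hydrogen on an aromatic carbon. Going by the values given here, no measured pair in the set shows this change, so nothing here fixes its size or direction. A small shift toward a lower number is expected for compound 3, that is a step of a 1.9-fold lower number from compound 2 to compound 3 (0.28 log units; within the scatter) in this assay , with a wide range around it. The estimate for compound 3 in this assay is 100000 nM, with a range from 30000 nM to 300000 nM.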

Compound 3, half-maximal inhibitory concentration: > 100000 nM
Compound 3 gave a limit, no number; the forecaster's own chance of this, stated with the estimate: 20%; the middle value lies on the limit itself.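

In this assay compound 3 gives > 100000 nM, a limit and not a number. For the compounds shown here, no step from compound 2 to compound 3 can therefore be read. The compounds shown leave open whether chloro in place of hydrogen on an aromatic carbon shifts the number, and in which direction.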